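A few compounds are considered here, and "the series" means these few. Any claim that something is new, unique, unknown or untested is made for them only; others in the source may bear on it.

Among the compounds with values here, in a functional assay on Bel-7402 cells (Homo sapiens) for cytotoxicity, read by resazurin assay, with a stated time of 72 h (on this read-out higher numbers stand for weaker inhibition and lower numbers for stronger inhibition), compound 2 `CCCCOC(=O)CCSC(=S)NCc1cccnc1` gives 6350 nM, one of only two numbers so far; the other belongs to compound 1 `O=C(O)CCSC(=S)NCc1cccnc1`, which gives 7420 nM, and the two lie within the scatter of each other. Compound 3 `NC(=O)CCSC(=S)NCc1cccnc1` differs from compound 2 by amino in place of butoxy on a carbonyl carbon. Within the data shown here, the only measured step that touches this carbonyl carbon is a 1.2-fold lower number from compound 1 to compound 2 (0.07 log units; within the scatter), which gives no direction to build on, so no step beyond the scatter is expected here. Compound 3 is therefore estimated at 7000 nM, between 3000 nM and 17000 nM, an expected step of a 1.1-fold higher number from compound 2 to compound 3 (0.04 log units; within the scatter).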

Compound 3, half-maximal inhibitory concentration: 3330 nM
Estimate against measurement, compound 3: 2.1-fold (0.32 log units) above; measured number inside the range.
By their numbers in this assay, from the lowest: compounds 3, 2 and 1 (each within the scatter of the next, the first and the last beyond it).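

Within the data shown here, on the carbonyl carbon, amino gives the only step so far beyond the scatter in this assay, a modest one: a 2.2-fold lower number from compound 1 to compound 3 (0.35 log units; beyond the scatter), in place of hydroxy. Against butoxy the same group stays inside the scatter, with a 1.9-fold lower number from compound 2 to compound 3 (0.28 log units; within the scatter), so only the exchange of hydroxy for amino can be read as a change at this position. Nothing at hand accounts for this difference.

The compounds shown leave open whether a methylamino or dimethylamino group on this carbonyl carbon would keep that step. They also leave open whether a shorter group such as methoxy would stand with butoxy.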